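From Ethyl to 4-Cyclopropylphenyl on the Ring Nitrogen

This account rests on a few compounds, and the source may have more. Where it says the series, first, only, none or still open, it means among the compounds named here.

Three measured compounds share one core and differ only at the amide-type nitrogen in the ring. Compound 1 `COc1cccc(OC)c1N1C(=O)CSC1c1cccc(C(=O)NCCCCc2ccccc2)c1` carries 2,6-dimethoxyphenyl there, and in a functional assay on HOS-TE85 cells (Homo sapiens) for inhibition, read by CCK-8 assay, with a stated time of 72 h (a lower number here means a stronger inhibitor, a higher number a weaker inhibitor), compound 1 reaches only the limit > 1000 nM. Compound 2 `CCN(CC)c1ccc(N2C(=O)CSC2c2cccc(C(=O)NCCCCc3ccccc3)c2)cc1` bears 4-(diethylamino)phenyl; in this assay compound 2 likewise gives the limit > 1000 nM. Compound 3 `CCN1C(=O)CSC1c1cccc(C(=O)NCCCCc2ccccc2)c1` carries ethyl, and in this assay compound 3 also gives the limit > 1000 nM. Because (the limit of > 1000 nM in this assay, at which 3 of the 3 values shown sit), the steps a step that the two limits leave unreadable from compound 1 to compound 2, a step that the two limits leave unreadable from compound 1 to compound 3 and a step that the two limits leave unreadable from compound 2 to compound 3 cannot be sized. Compound 4 `O=C(NCCCCc1ccccc1)c1cccc(C2SCC(=O)N2c2ccc(C3CC3)cc2)c1` differs from compound 3 by 4-cyclopropylphenyl in place of ethyl on an amide-type nitrogen in a ring. Given (the limit of > 1000 nM in this assay, at which 3 of the 3 values shown sit), compound 4 is expected to stay weak, at an estimated 3000 nM (range 700 nM to 20000 nM). The step is estimated as a step that the limit leaves unreadable from compound 3 to compound 4.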

Compound 4, half-maximal inhibitory concentration: 217 nM
Estimate against measurement, compound 4: 14-fold (1.14 log units) above, and the stated range ends above it.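

In this assay, for the compounds shown here, the amide-type nitrogen in the ring now has a group that gives a readable value, which the earlier compounds did not show: the limit of > 1000 nM in this assay, at which 3 of the 4 values shown sit. Replacing ethyl with 4-cyclopropylphenyl gives an at least 4.6-fold lower number from compound 3 to compound 4 (0.66 log units; beyond the scatter), cyclopropyl in place of diethylamino gives an at least 4.6-fold lower number from compound 2 to compound 4 (0.66 log units; beyond the scatter), and the change of aryl group gives an at least 4.6-fold lower number from compound 1 to compound 4 (0.66 log units; beyond the scatter). A phenyl ring at this nitrogen is thus not enough by itself, as compound 1 and compound 2 go against any such pattern, so the substitution on that ring matters here.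

From the compounds shown here alone, it remains open whether 4-isopropylphenyl or 4-methoxyphenyl would match compound 4. Going by these compounds, whether an unsubstituted phenyl or a cyclopropyl directly on the nitrogen would also do so is equally open.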